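The source may report more compounds than this note shows. Statements on the series, on what has been measured and on what is new or still open speak of the compounds shown alone.

Measured so far:
Compound 1, `c1coc(CNCCCNc2ccnc3cc(CC4CCCCC4)ccc23)c1`: 1700 nM
Compound 2, `c1coc(CNCCCNc2ccnc3cc(-c4cccc5ccccc45)ccc23)c1`: 5600 nM
Compound 3, `CCC(CC)c1ccc2c(NCCCNCc3ccco3)ccnc2c1`: 6760 nM

These three share one core and differ only in the group on one aromatic carbon. In an ADME assay on HepG2 cells (Homo sapiens) for cytotoxicity, read by luminescence, CellTiter-Glo and ATP content, with a stated time of 72 h (a higher number here means that more compound is needed for the effect, a lower number that less compound is needed), compound 3 gives 6760 nM. Its number lies close to that of compound 2, a 1.2-fold higher number from compound 2 to compound 3 (0.08 log units; within the scatter), and apart from that of compound 1, a 4.0-fold higher number from compound 1 to compound 3 (0.60 log units; beyond the scatter).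

Compound 4, `N#Cc1ccc(Cc2ccc3c(NCCCNCc4ccco4)ccnc3c2)cc1`, has not yet been measured. It differs from compound 3 in one place: 4-cyanobenzyl in place of pentan-3-yl on an aromatic carbon. Going by the values given here, two measured steps bear on this. The swap of cyclohexylmethyl for pentan-3-yl gave a 4.0-fold higher number from compound 1 to compound 3 (0.60 log units; beyond the scatter), while the swap of naphthalen-1-yl for pentan-3-yl gave a 1.2-fold higher number from compound 2 to compound 3 (0.08 log units; within the scatter). The entering 4-cyanobenzyl carries an aromatic ring, like naphthalen-1-yl, joined through one carbon, like cyclohexylmethyl. Among the compounds with values here, no measured pair shows a nitrile. The step expected here is a 1.4-fold lower number from compound 3 to compound 4 (0.13 log units; within the scatter), a small shift downward that may stay within the scatter. Compound 4 is therefore estimated to give 5000 nM, with a range from 1500 nM to 15000 nM.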

Compound 4, half-maximal effective concentration: 7910 nM
The estimate for compound 4 lay 1.6-fold (0.20 log units) below the measured number; the measured number falls inside the stated range.
By their numbers in this assay, from the lowest: compound 1; then compounds 2, 3 and 4 (each within the scatter of the next).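

Replacing pentan-3-yl with 4-cyanobenzyl gives (a 1.2-fold higher number from compound 3 to compound 4 (0.07 log units; within the scatter)) and replacing naphthalen-1-yl with it gives (a 1.4-fold higher number from compound 2 to compound 4 (0.15 log units; within the scatter)), so in this assay these three quite different groups on this aromatic carbon cannot be told apart. The saturated chain carbon attached to the core does not by itself give the low number of compound 1: compound 4 keeps that carbon, yet 4-cyanophenyl in place of cyclohexyl gives (a 4.7-fold higher number from compound 1 to compound 4 (0.67 log units; beyond the scatter)). Nothing measured here explains why cyclohexylmethyl stands apart.

As far as these compounds go, whether the nitrile or the aromatic ring matters in that last step remains open, and a plain benzyl group would separate the two. A cyclohexyl group joined directly to the core, or a chain ending in an amine, would test how far the effect of cyclohexylmethyl extends.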